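A few compounds are considered here, and "the series" means these few. Any claim that something is new, unique, unknown or untested is made for them only; others in the source may bear on it.

In a functional assay for inhibition (a lower number here means a stronger inhibitor, a higher number a weaker inhibitor), compound 1 `CC(C)(C)c1cc(-c2cc(=O)c3ccc(OCCCS(=O)(=O)O)cc3o2)cc(C(C)(C)C)c1O` gives 500 nM and compound 2 `CC(C)(C)c1cc(-c2cc(=O)c3ccccc3o2)cc(C(C)(C)C)c1O` gives 3000 nM, the higher of the two numbers. Compound 3 `CCN(CC)C(=O)COc1ccc2c(=O)cc(-c3cc(C(C)(C)C)c(O)c(C(C)(C)C)c3)oc2c1` differs from compound 2 by (diethylcarbamoyl)methoxy in place of hydrogen on an aromatic carbon, with (diethylcarbamoyl)methoxy in place of hydrogen on an aromatic carbon. Going by the values given here, only one measured step bears on this change: a 6.0-fold higher number from compound 1 to compound 2 (0.78 log units; beyond the scatter), a modest step with hydrogen in place of 3-sulfopropoxy. Read in reverse, that step points to a lower number, but the entering group is a different one with no net charge, so a smaller drop in this assay is expected. The expected step is a 2.5-fold lower number from compound 2 to compound 3 (0.40 log units; beyond the scatter). For compound 3, the estimated value is 1200 nM, within a range of 300 nM to 4000 nM.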

Compound 3, half-maximal inhibitory concentration: 3000 nM
The estimate for compound 3 lay 2.5-fold (0.40 log units) below the measured number; low and high end bracket the measured number.
By their numbers in this assay, from the lowest: compound 1; then compounds 2 and 3 (each within the scatter of the next).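

In this assay, (diethylcarbamoyl)methoxy on this aromatic carbon gives no change at the digits printed from compound 2 to compound 3 (within the scatter), so a group at this place does not by itself lower the number. Diethylcarbamoyl in place of 2-sulfoethyl on the same chain gives a 6.0-fold higher number from compound 1 to compound 3 (0.78 log units; beyond the scatter), which ties the lower number of compound 1 to the end of the chain among these three compounds. Nothing available explains this difference. On these data alone, it remains open whether a carboxylic acid or an amine at the chain end would match the sulfonic acid of compound 1, and how a longer chain would read.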